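From a phenyl end group to 3-hydroxyphenoxy

The source may hold more compounds than are shown below. What is called first, only, known or untested is meant among the compounds shown, and "the series" means these compounds.

Compound 1 `O=C(O)c1cc(=O)c2ccc(OCCCCCOc3ccccc3)cc2o1` gives 0.4 ug/mL
Compound 2 `O=C(O)c1cc(=O)c2ccc(OCCCCCSc3ccccc3)cc2o1` gives 0.4 ug/mL
Compound 3 `O=C(O)c1cc(=O)c2ccc(OCCCCCc3ccccc3)cc2o1` gives 0.6 ug/mL

In a functional assay on ileum (Cavia porcellus) for antagonist activity, with a stated time of 30 s (a higher number here means a weaker inhibitor, a lower number a stronger inhibitor), compound 3 gives 0.6 ug/mL, which lies within the scatter of the other two values. Compound 4 `O=C(O)c1cc(=O)c2ccc(OCCCCCOc3cccc(O)c3)cc2o1` has not been measured yet. Its difference from compound 3 is 3-hydroxyphenoxy in place of phenyl on a saturated chain carbon, five bonds along the chain from an oxygen on an aromatic ring.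

Exchanging the group at this place has so far moved the numbers very little. The measured steps are a 1.5-fold higher number from compound 1 to compound 3 (0.18 log units; within the scatter), a 1.5-fold higher number from compound 2 to compound 3 (0.18 log units; within the scatter) and no change at the digits printed from compound 1 to compound 2 (within the scatter) for the remaining pair. Compound 1, which holds phenoxy at that place, gives 0.4 ug/mL and is the nearest guide. For the measured compounds named here, no measured compound carries the added hydroxy, so its contribution is unknown and the range must stay wide.

The expected step is small, a 1.5-fold lower number from compound 3 to compound 4 (0.18 log units; within the scatter), with no change beyond the scatter foreseen. For compound 4 the estimate is 0.4 ug/mL, with an expected range from 0.12 ug/mL to 1.5 ug/mL.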

Compound 4, half-maximal inhibitory concentration: 1.5 ug/mL
For compound 4 the middle estimate is 3.8-fold (0.57 log units) below the measured one; the measured number falls inside the stated range.
By their numbers in this assay, from the lowest: compounds 1, 2 and 3 (each within the scatter of the next); then compound 4.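

In this assay the step for hydroxy in place of hydrogen on an aromatic carbon is a 3.8-fold higher number from compound 1 to compound 4 (0.57 log units; beyond the scatter) and gives a weaker inhibitor, so this end group does respond to change, even though exchanging phenoxy, phenylsulfanyl and phenyl among themselves stayed within the scatter. Compound 4 also stands apart from the other two end groups, with a 3.8-fold higher number from compound 2 to compound 4 (0.57 log units; beyond the scatter) and a 2.5-fold higher number from compound 3 to compound 4 (0.40 log units; beyond the scatter) as the remaining steps, which places it last of the four in this series. No measurement here explains why the added hydroxy weakens inhibition.

As far as these compounds go, it remains open whether this loss is specific to hydroxy or would also appear with a methoxy group or an amine in its place. Whether a longer chain would change the effect of the hydroxy is also unknown.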